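Acetamido for Fluoro on the Sulfonyl Aryl Ring

This account rests on a few compounds, and the source may have more. Where it says the series, first, only, none or still open, it means among the compounds named here.

Compound 1 `O=C1/C(=C/c2ccccc2F)CN(S(=O)(=O)c2ccc(C(F)(F)F)cc2)C/C1=C\c1ccccc1F`: 16200 nM
Compound 2 `O=C1/C(=C/c2ccccc2F)CN(S(=O)(=O)c2ccc(F)cc2)C/C1=C\c1ccccc1F`: 17500 nM
Compound 3 `O=C1/C(=C/c2ccccc2F)CN(S(=O)(=O)c2ccc(Cl)cc2)C/C1=C\c1ccccc1F`: 14100 nM

In an ADME assay on L02 cells (Homo sapiens) for cytotoxicity, read by MTT assay, with a stated time of 24 h (on this read-out higher numbers stand for weaker inhibition and lower numbers for stronger inhibition), compound 2 gives 17500 nM, the highest of the three numbers, though its gaps to compound 1 and compound 3 both lie within the scatter. Compound 4 `CC(=O)Nc1ccc(S(=O)(=O)N2C/C(=C\c3ccccc3F)C(=O)/C(=C/c3ccccc3F)C2)cc1` differs from compound 2 by acetamido in place of fluoro on an aromatic carbon. The measured steps all exchange one substituent on that same aromatic carbon: a 1.1-fold higher number from compound 1 to compound 2 (0.03 log units; within the scatter), a 1.1-fold lower number from compound 1 to compound 3 (0.06 log units; within the scatter) and a 1.2-fold lower number from compound 2 to compound 3 (0.09 log units; within the scatter), none beyond the scatter. For the measured compounds named here, no measured step introduces an acetamido group or any group with a hydrogen-bond donor, so the expectation rests on the flatness seen so far. Compound 4 is therefore expected to show no step beyond the scatter, a 1.0-fold lower number from compound 2 to compound 4 (0.01 log units; within the scatter). The estimate for compound 4 is 17000 nM, within 8000 nM to 36000 nM.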

Compound 4, half-maximal inhibitory concentration: 11500 nM
The estimate for compound 4 lay 1.5-fold (0.17 log units) above the measured number; measured number inside the range.
By their numbers in this assay, from the lowest: compounds 4, 3, 1 and 2 (each within the scatter of the next).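

In this assay, for the compounds shown here, the acetamido group, the only group here with a hydrogen-bond donor, stays within the scatter of all three earlier substituents on this aromatic carbon (a 1.5-fold lower number from compound 2 to compound 4 (0.18 log units; within the scatter); a 1.2-fold lower number from compound 3 to compound 4 (0.09 log units; within the scatter); a 1.4-fold lower number from compound 1 to compound 4 (0.15 log units; within the scatter)). The flat picture therefore extends from the halogens and trifluoromethyl to a larger amide substituent at this position. No measurement bears on why these numbers stay so close. The compounds shown leave open whether an amine or a carboxylic acid on this aromatic carbon would also stay within the scatter. They also leave open whether changes elsewhere on the shared core would do so.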